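A few compounds are considered here, and "the series" means these few. Any claim that something is new, unique, unknown or untested is made for them only; others in the source may bear on it.

Measured so far:
compound 1 `O=C1O[C@H]([C@@H](O)Cn2cc(-c3cc(C(F)(F)F)cc(C(F)(F)F)c3)nn2)C(OCc2ccccc2)=C1OCc1ccccc1` gives 45900 nM in a functional assay on MCF7 cells (Homo sapiens) for antiproliferative activity, read by MTT assay, with a stated time of 72 h; a higher number here means a weaker inhibitor, a lower number a stronger inhibitor.
compound 2 `O=C1O/C(=C\Cn2cc(-c3cc(F)cc(F)c3)nn2)C(OCc2ccccc2)=C1OCc1ccccc1` gives > 100000 nM; this is a limit of the assay, not a number.
compound 3 `CCCCc1cn(C[C@H](O)[C@H]2OC(=O)C(OCc3ccccc3)=C2OCc2ccccc2)nn1` gives 7910 nM in this assay.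

Of the two numbers in hand, compound 3 holds the lower one; compound 1 sits higher by a gap that is beyond the scatter of repeat runs. Compound 2 contributes nothing to the ordering beyond (the limit of > 100000 nM in this assay, at which 1 of the 3 values shown sits).

Compound 4 `Cc1ccc(S(=O)(=O)NCc2cn(C[C@H](O)[C@H]3OC(=O)C(OCc4ccccc4)=C3OCc3ccccc3)nn2)cc1` differs from compound 3 in one place: ((4-methylphenyl)sulfonyl)amino in place of propyl on a saturated chain carbon bound to an aromatic carbon. Among the compounds with values here, no pair of measured compounds covers a change of this kind, so the series itself gives no reading of how such a swap shifts the number. With no guidance either way, the step from compound 3 to compound 4 is expected to be small, not clearly beyond the scatter in either direction, a 1.1-fold higher number from compound 3 to compound 4 (0.06 log units; within the scatter). Compound 4 is therefore expected to land near 9000 nM in this assay, with a plausible span from 2500 nM to 35000 nM, the width reflecting that the entering group is unlike anything else measured here.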

Compound 4, half-maximal inhibitory concentration: 6400 nM
Estimate against measurement, compound 4: 1.4-fold (0.15 log units) above; low and high end bracket the measured number.
By their numbers in this assay, from the lowest: compounds 4 and 3 (each within the scatter of the next); then compound 1. At a limit, above all of these: compound 2.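

Within the data shown here, replacing propyl with ((4-methylphenyl)sulfonyl)amino on a saturated chain carbon bound to an aromatic carbon gives a 1.2-fold lower number from compound 3 to compound 4 (0.09 log units; within the scatter) in this assay, the first reading of a change made in one place. This position therefore accepts a much larger group, carrying a six-membered aromatic ring, a hydrogen-bond donor and hydrogen-bond acceptors, without a shift in the number that stands clear of the scatter. No measured property shown here bears on why the number holds across this change.

As far as these compounds go, whether any group at this position can move the number beyond the scatter remains open. A primary amine, a carboxylic acid or a longer alkyl chain in this place would show whether the insensitivity seen with this single pair extends further.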